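The compounds below may be only part of what the source reports. "The series", "measured", "known", "first", "only" and "open" are said of these compounds alone.

Measured compounds in a functional assay on HL-60 cells (Homo sapiens) for cytotoxicity, read by luminescence; on this read-out higher numbers stand for weaker inhibition and lower numbers for stronger inhibition:
compound 1, `C=C(CC)C(=O)c1ccc(OCC(=O)NCCNS(=O)(=O)c2ccc(OC)cc2OC)c(Cl)c1Cl`, gives 2790 nM
compound 2, `C=C(CC)C(=O)c1ccc(OCC(=O)NCCNS(=O)(=O)c2cc(Cl)ccc2OC)c(Cl)c1Cl`, gives 1600 nM
compound 3, `C=C(CC)C(=O)c1ccc(OCC(=O)NC2CCN(S(=O)(=O)c3ccc(OC)cc3OC)CC2)c(Cl)c1Cl`, gives 860 nM

Compound 1 and compound 2 differ in one place: 5-chloro-2-methoxyphenyl in place of 2,4-dimethoxyphenyl on a sulfonyl sulfur. That change gave a 1.7-fold lower number from compound 1 to compound 2 (0.24 log units; within the scatter). Compound 4, `C=C(CC)C(=O)c1ccc(OCC(=O)NC2CCN(S(=O)(=O)c3cc(Cl)ccc3OC)CC2)c(Cl)c1Cl`, has not yet been measured; relative to compound 3 it carries the same kind of change: 5-chloro-2-methoxyphenyl in place of 2,4-dimethoxyphenyl on a sulfonyl sulfur. The two places are not identical: in compound 1 the sulfonyl sulfur's other neighbour is a sulfonamide nitrogen, while in compound 3 it is a sulfonamide nitrogen in a ring. How the core of compound 3 differs from the core of compound 1 is not broken down here. Because the earlier change gave a 1.7-fold lower number from compound 1 to compound 2 (0.24 log units; within the scatter), a step of similar size is expected for a 1.7-fold lower number from compound 3 to compound 4 (0.24 log units; within the scatter). Compound 4 is therefore estimated at 500 nM in this assay, with a likely range from 200 nM to 1300 nM.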

Compound 4, half-maximal inhibitory concentration: 700 nM
Estimate against measurement, compound 4: 1.4-fold (0.15 log units) below; the range from low to high includes it.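

In this assay the swap of 2,4-dimethoxyphenyl for 5-chloro-2-methoxyphenyl on the sulfonyl sulfur gave a 1.2-fold lower number from compound 3 to compound 4 (0.09 log units; within the scatter), and the earlier step on the other core tells the same story: the same change on two cores in this assay, a 1.7-fold lower number (0.24 log units; within the scatter) from compound 1 to compound 2 and a 1.2-fold lower number (0.09 log units; within the scatter) from compound 3 to compound 4, 1.4-fold (0.15 log units) apart, within the scatter of two such steps. So on these two cores the change behaves alike, with no sign that the core alters its effect. Yet each step is itself within the scatter, so this does not show that the change truly alters the read-out, and two cores say nothing about other cores.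

From the compounds shown here alone, it remains open what an amine or a carboxylic acid in place of the chlorine would do. Equally open, going by these compounds, is whether the change would behave alike on a core with a longer chain.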